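Shortening the chain on the aromatic nitrogen: propyl to methyl

The source may report more compounds than this note shows. Statements on the series, on what has been measured and on what is new or still open speak of the compounds shown alone.

Compound 2 `CCCn1c(-c2ccco2)nc2c(N)ncnc21` stands lowest of the three numbers in an assay on CHO cells for displacement of a labelled ligand from adenosine receptor A3 (Homo sapiens) (on this read-out higher numbers stand for weaker inhibition and lower numbers for stronger inhibition), with 790 nM. Compound 1 `Nc1ncnc2c1nc(-c1ccco1)n2CCCO` gives 4300 nM, and compound 3 `Cc1ccc(NC(=O)Nc2ncnc3c2nc(-c2ccco2)n3C)cc1` gives 38000 nM. Going by the values given here, the only single-point step in the set, a 5.4-fold lower number from compound 1 to compound 2 (0.74 log units; beyond the scatter), changes the end of the same chain; no measured pair separates chain length alone. Compound 3 carries a methyl on the aromatic nitrogen but also a urea on the amine, so its number against that of compound 2 cannot be read as a chain effect.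

Compound 4 `Cn1c(-c2ccco2)nc2c(N)ncnc21` differs from compound 2 by hydrogen in place of ethyl on a saturated chain carbon bound to an aromatic nitrogen. Among the compounds with values here, the one step at the chain was modest and beyond the scatter; the change here sits closer to the ring and removes the chain bulk. For compound 4 the estimate is a step of a 3.2-fold higher number from compound 2 to compound 4 (0.50 log units; beyond the scatter) in this assay, a modest increase in the number. Compound 4 is expected to give about 2500 nM, within a range of 800 nM to 8000 nM.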

Compound 4, inhibition constant: 6420 nM
Compound 4: middle estimate off by 2.6-fold (0.41 log units), on the low side, within the range that was stated.
By their numbers in this assay, from the lowest: compound 2; then compounds 1 and 4 (each within the scatter of the next); then compound 3.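

In this assay, chain length at this position now stands apart from other changes: hydrogen in place of ethyl on a saturated chain carbon bound to an aromatic nitrogen gives an 8.1-fold higher number from compound 2 to compound 4 (0.91 log units; beyond the scatter) and leaves compound 2 with the lowest number of the series. Hydrogen in place of 2-hydroxyethyl gives a 1.5-fold higher number from compound 1 to compound 4 (0.17 log units; within the scatter) and so does not separate the hydroxy-ended chain of compound 1 from the methyl of compound 4; among these compounds, the propyl chain alone stands apart from methyl. No measurement at hand bears on what lies behind these steps.

Still open, on these data alone, is how an ethyl or butyl chain at this position would read, and whether an amine or a carboxylic acid at the chain end would match the hydroxy of compound 1. Also open, as far as these compounds go, is how the urea of compound 3 would read with a propyl chain in place of methyl.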